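This account rests on a few compounds, and the source may have more. Where it says the series, first, only, none or still open, it means among the compounds named here.

In a functional assay on T-24 cells (Homo sapiens) for antiproliferative activity, read by MTT assay, with a stated time of 72 h (on this read-out higher numbers stand for weaker inhibition and lower numbers for stronger inhibition), compound 1 `N=C(NC(=N)NC1CCCC1)Nc1ccc(C(F)(F)F)cc1` gives 3700 nM. Among the compounds with values here, this is the lower of the two numbers available so far, which means the stronger inhibition. Compound 2 `N=C(NC(=N)NC1CCCC1)Nc1ccc(F)cc1F` gives 37800 nM, a gap well beyond the usual scatter of repeated measurements. The next compound to be tested is compound 3 `CCN(CC)C(=N)NC(=N)Nc1ccc(C(F)(F)F)cc1`. It keeps the rest of compound 1 but carries diethylamino in place of cyclopentylamino on a carbon with a double bond to nitrogen. Within the data shown here, no pair of measured compounds isolates this change, so there is no direct precedent and any forecast has to stay loose. A modest weakening in this assay is expected, and the estimated step is a 2.2-fold higher number from compound 1 to compound 3 (0.33 log units; beyond the scatter). For compound 3 the expected value is 8000 nM, with an estimated range from 2500 nM to 30000 nM.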

Compound 3, half-maximal inhibitory concentration: 6200 nM
Compound 3: middle estimate off by 1.3-fold (0.11 log units), on the high side; the measured number falls inside the stated range.
By their numbers in this assay, from the lowest: compounds 1 and 3 (each within the scatter of the next); then compound 2.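

In this assay, putting diethylamino in place of cyclopentylamino gives a 1.7-fold higher number from compound 1 to compound 3 (0.22 log units; within the scatter) and so leaves the reading at this position indistinguishable from that of the parent compound. Within the data shown here, this is the first sign of what the position accepts: the five-membered ring can give way to two open ethyl chains, and the hydrogen-bond donor counted on the cyclopentylamino group can go, with no change beyond the usual scatter. Nothing available here explains why the two groups read alike.

Still open, as far as these compounds go, is how far this tolerance extends, for example to a much smaller group such as plain amino, to a longer chain such as dibutylamino, or to a ring containing oxygen such as morpholine. From the compounds shown here alone, it also remains unknown whether the same swap would read alike when made on compound 2.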